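The source may report more compounds than this note shows. Statements on the series, on what has been measured and on what is new or still open speak of the compounds shown alone.

The measured compounds in a functional assay on HCT-116 cells (Homo sapiens) for antiproliferative activity, read by MTT assay, with a stated time of 48 h (on this read-out lower numbers stand for stronger inhibition and higher numbers for weaker inhibition), are these:
Compound 1, `COc1cc(/C=C/C(C)=O)ccc1OCc1cn(-c2ccc(NC(=O)c3ccccc3)cc2)nn1`, gives > 100000 nM, which is a limit of the assay and not a number.
Compound 2, `COc1cc(/C=C/C(C)=O)ccc1OCc1cn(-c2ccc([N+](=O)[O-])cc2)nn1`, gives 96300 nM.
Compound 3, `COc1cc(/C=C/C(C)=O)ccc1OCc1cn(-c2ccccc2Cl)nn1`, gives 39000 nM.

Among the two actual numbers, compound 3 stands lowest. Its nearest neighbour is compound 2, and the step of a 2.5-fold lower number from compound 2 to compound 3 (0.39 log units; beyond the scatter) lies beyond the scatter. For the measured compounds named here, for compound 1 only a limit is known, (the limit of > 100000 nM in this assay, at which 1 of the 3 values shown sits), so no step from it to compound 3 can be sized. The step of an at least 1.0-fold lower number from compound 1 to compound 2 (0.01 log units; that floor lies within the scatter) sits at that limit and stays within the scatter, so the benzamido and nitro variants cannot be told apart.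

Compound 4, `COc1cc(/C=C/C(C)=O)ccc1OCc1cn(-c2ccc(C=O)cc2)nn1`, is not yet measured. It differs from compound 3 in one place: 4-formylphenyl in place of 2-chlorophenyl on an aromatic nitrogen. The step that bears on this is a 2.5-fold lower number from compound 2 to compound 3 (0.39 log units; beyond the scatter), in which a 2-chlorophenyl took the place of a 4-nitrophenyl and the number fell modestly; compound 4 now gives up the 2-chlorophenyl for another 4-substituted phenyl. Going by the values given here, no measured compound carries a formyl group, so the size is uncertain. Compound 4 is therefore expected to give a modestly higher number than compound 3, estimated at 80000 nM in this assay, with a range from 30000 nM to 200000 nM. That expected step is a 2.1-fold higher number from compound 3 to compound 4 (0.31 log units; beyond the scatter).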

Compound 4, half-maximal inhibitory concentration: 76200 nM
For compound 4 the middle estimate is 1.0-fold (0.02 log units) above the measured one; the range from low to high includes it.
By their numbers in this assay, from the lowest: compounds 3, 4 and 2 (each within the scatter of the next, the first and the last beyond it). At a limit, above all of these: compound 1.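

In this assay, placing formyl where nitro stood gives a 1.3-fold lower number from compound 2 to compound 4 (0.10 log units; within the scatter), and placing 4-formylphenyl where 2-chlorophenyl stood gives a 2.0-fold higher number from compound 3 to compound 4 (0.29 log units; within the scatter). Both steps lie within the scatter, so on this aromatic nitrogen of the triazole-like five-membered ring the 4-formylphenyl cannot be told apart from either the 4-nitrophenyl or the 2-chlorophenyl, even though compound 2 and compound 3 are separated by more than the scatter. Compound 1 gives > 100000 nM, which is a limit of the assay and not a number. Placing formyl where benzamido stood gives an at least 1.3-fold lower number from compound 1 to compound 4 (0.11 log units; that floor lies within the scatter), a step that sits at that limit: the limit of > 100000 nM in this assay, at which 1 of the 4 values shown sits.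

From the compounds shown here alone, it remains open whether an amine or a carboxylic acid in place of the formyl on this phenyl would move the number beyond the scatter. A plain phenyl on the same nitrogen would also be needed to show what the chlorine and the 4-substituents each contribute.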